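The source may report more compounds than this note shows. Statements on the series, on what has been measured and on what is new or still open speak of the compounds shown alone.

Measured in an ADME assay on K562 cells (Homo sapiens) for cytotoxicity, with a stated time of 72 h; on this read-out higher numbers stand for weaker inhibition and lower numbers for stronger inhibition:

- Compound 1 `COc1ccc(CNc2ncnc3c2ncn3C2CCCCO2)c(OC)c1`: > 25000 nM (a limit)
- Compound 2 `COc1ccc(CNc2ncnc3c2ncn3C2CCCCO2)cc1OC`: > 100000 nM (a limit)

Compound 2 has only a limit here, not a number. The one other result, for compound 1, is also a limit, so the two compounds cannot be put in order.

Compound 3 `COc1ccc(CNc2ncnc3c2ncn3C2CCCCO2)c(OC)c1OC` differs from compound 2 in one place: methoxy in place of hydrogen on an aromatic carbon. In words, a methoxy takes the place of a hydrogen on an aromatic carbon. No measured single change is available to show how large such a step might be. The expectation therefore rests on the limit of compound 2, > 100000 nM.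

Weak inhibition is expected again, with no change beyond the usual scatter in this assay. The expected step is an at least 1.4-fold lower number from compound 2 to compound 3 (0.15 log units; that floor lies within the scatter). Compound 3 is estimated at 70000 nM, with an expected range of 20000 nM to 200000 nM.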

Compound 3, half-maximal inhibitory concentration: > 37500 nM
Compound 3: no number, only a limit; the forecaster's own chance of this, stated with the estimate: 80%; the middle value does not contradict the limit.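

Compound 3 also gives only a limit in this assay, as do compound 1 and compound 2, so neither step to compound 3 can be read. The compounds shown leave open where any of them would reach half-maximal inhibition, and what the added methoxy changes.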